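The compounds below may be only part of what the source reports. "The series", "measured", "known", "first", "only" and "open" are said of these compounds alone.

Measured so far:
Compound 1, `N#Cc1ccc(-c2nc(N)c3cc(Cc4ccccc4)sc3n2)o1`: 3160 nM
Compound 2, `Nc1nc(-c2cnco2)nc2sc(Cc3ccccc3)cc12`: 106 nM

In a functional assay on CHO-K1 cells for antagonist activity at adenosine receptor A1 (Homo sapiens), read by a beta-galactosidase reporter and cAMP accumulation, with stated times of 15 min and 6 h (on this read-out higher numbers stand for weaker inhibition and lower numbers for stronger inhibition), compound 1 gives 3160 nM, while compound 2 gives 106 nM. Going by the values given here, the single measured step, a 30-fold lower number from compound 1 to compound 2 (1.47 log units; beyond the scatter), shows that the five-membered ring at this position of the shared core strongly sets the read-out. On the two numbers shown, compound 2 stands lowest, with compound 1 the only neighbour.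

Compound 3, `Cc1nc(-c2nc(N)c3cc(Cc4ccccc4)sc3n2)cs1`, has not yet been measured. It differs from compound 2 by 2-methyl-1,3-thiazol-4-yl in place of 1,3-oxazol-5-yl on an aromatic carbon. Among the compounds with values here, no measured step directly compares these two rings; the only step known, from compound 1 to compound 2, swaps one heteroaryl for another and was large, so a change of either direction beyond the scatter cannot be ruled out. Compound 3 is expected to give about 220 nM, between 50 nM and 900 nM. The step of a 2.1-fold higher number from compound 2 to compound 3 (0.32 log units; beyond the scatter) is therefore estimated to be modest.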

Compound 3, inhibition constant: 263 nM
The estimate for compound 3 lay 1.2-fold (0.08 log units) below the measured number; measured number inside the range.
By their numbers in this assay, from the lowest: compound 2; then compound 3; then compound 1.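

In this assay, the 2-methyl-1,3-thiazol-4-yl ring does not match 1,3-oxazol-5-yl, with a 2.5-fold higher number from compound 2 to compound 3 (0.39 log units; beyond the scatter), so this position separates even two five-membered aromatic rings that have the same counts of hetero atoms and hydrogen-bond acceptors. Yet the replacement of 5-cyanofuran-2-yl by 2-methyl-1,3-thiazol-4-yl still gives a 12-fold lower number from compound 1 to compound 3 (1.08 log units; beyond the scatter), which shows that a large drop from compound 1 is not confined to the 1,3-oxazol-5-yl ring. Nothing available explains either step.

The change from compound 2 to compound 3 swaps the ring and adds a methyl group at once, so the compounds shown cannot separate the two, and an unsubstituted 1,3-thiazol-4-yl ring would be needed to do so. From the compounds shown here alone, it also remains open how a non-aromatic group at this carbon, such as an amine or a carboxylic acid, would read out.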